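Chloro to bromo on a nicotinoyl hydrazone

The source may report more compounds than this note shows. Statements on the series, on what has been measured and on what is new or still open speak of the compounds shown alone.

Measured so far:
compound 1 `O=C(N/N=C/c1ccccc1)c1cccnc1` — > 100 ug/mL
compound 2 `O=C(N/N=C/c1cccc(Cl)c1)c1cccnc1` — 53 ug/mL

In an ADME assay on HEL cells (Homo sapiens) for cytotoxicity, read by microscopy (on this read-out higher numbers stand for lower toxicity in this test and lower numbers for higher toxicity in this test), compound 1 gives only a limit, > 100 ug/mL, at the edge of the assay (the limit of > 100 ug/mL in this assay, at which 1 of the 2 values shown sits). Going by the values given here, compound 2 is the one compound with a numerical value here, giving 53 ug/mL. Among the compounds with values here, the single step between them, an at least 1.8-fold lower number from compound 1 to compound 2 (0.27 log units; that floor lies within the scatter), comes from a chloro in place of a hydrogen on an aromatic carbon, and its size is only a floor. Compound 3 `O=C(N/N=C/c1cccc(Br)c1)c1cccnc1` differs from compound 2 by bromo in place of chloro on an aromatic carbon. Within the data shown here, no measured step exchanges one halogen for another, so the bromo step has no direct precedent; the one step seen is a halogen entering where hydrogen stood, and that is a different kind of change. He therefore expects no step beyond the scatter, a 1.1-fold lower number from compound 2 to compound 3 (0.03 log units; within the scatter), for compound 3. His estimate for compound 3 in this assay is 50 ug/mL, between 25 ug/mL and 100 ug/mL.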

Compound 3, half-maximal cytotoxic concentration: 55 ug/mL
Compound 3: the middle estimate sits 1.1-fold (0.04 log units) below what was measured, and the stated range covers the measured number.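

Bromo in place of chloro on an aromatic carbon, meta to a large group, gives a 1.0-fold higher number from compound 2 to compound 3 (0.02 log units; within the scatter) in this assay, so the two halogens cannot be told apart at this position in this test. Bromo in place of hydrogen gives an at least 1.8-fold lower number from compound 1 to compound 3 (0.25 log units; that floor lies within the scatter), which is a second floor of the same kind as the one seen with chloro. Compound 1 gives only a limit, so neither floor shows the full size of the step from hydrogen to a halogen: the limit of > 100 ug/mL in this assay, at which 1 of the 3 values shown sits.

The compounds shown leave open whether a group other than a halogen, such as an amine, a carboxylic acid or a methoxy group, would give a number like those of compound 2 and compound 3 at this position. They also leave open how far the number lies from that of the unsubstituted compound 1.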